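A few compounds are considered here, and "the series" means these few. Any claim that something is new, unique, unknown or untested is made for them only; others in the source may bear on it.

Compound 3 `CSc1ncnc2c1c(-c1cccs1)cn2[C@@H]1O[C@H](CO)[C@@H](O)[C@H]1O` gives only a limit in a functional assay on HCT-116 cells (Homo sapiens), read by MTT assay, with a stated time of 72 h (a higher number here means a weaker inhibitor, a lower number a stronger inhibitor), namely > 20000 nM, so its standing among the numbers shown is open (the limit of > 20000 nM in this assay, at which 1 of the 3 values shown sits). Compound 4 `CSc1ncnc2c1c(-c1ccsc1)cn2[C@@H]1O[C@H](CO)[C@@H](O)[C@H]1O` differs from it by thiophen-3-yl in place of thiophen-2-yl on an aromatic carbon. For the measured compounds named here, no measured step covers this change. Going by the values given here, the one measured step, a 10-fold higher number from compound 1 to compound 2 (1.01 log units; beyond the scatter), concerns the substituent on the six-membered ring, not the thiophene, and was large. Compound 1 `COc1ncnc2c1c(-c1ccsc1)cn2[C@@H]1O[C@H](CO)[C@@H](O)[C@H]1O` gives 140 nM in this assay. Compound 2 `Cc1ncnc2c1c(-c1ccsc1)cn2[C@@H]1O[C@H](CO)[C@@H](O)[C@H]1O` gives 1430 nM in this assay. Both carry thiophen-3-yl with a number rather than a limit, so compound 4 is expected to return a measurable value, an estimated 5000 nM, in the range 800 nM to 25000 nM. The expected change is therefore an at least 4.0-fold lower number from compound 3 to compound 4 (0.60 log units; beyond the scatter), toward stronger inhibition, though the limit on compound 3 leaves its size uncertain.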

Compound 4, half-maximal inhibitory concentration: > 20000 nM
Compound 4 ended at the assay's limit (the forecaster's own chance of this, stated with the estimate: 35%); at least 4.0-fold (0.60 log units) between middle value and limit.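

Compound 4 stands at a limit in this assay, not at a number: the limit of > 20000 nM in this assay, at which 2 of the 4 values shown sit. Both compounds of the thiophene swap are limits, so that step cannot be read. With thiophen-3-yl kept, methylsulfanyl in place of methyl gives an at least 13-fold higher number from compound 2 to compound 4 (1.14 log units; beyond the scatter) and methylsulfanyl in place of methoxy gives an at least 140-fold higher number from compound 1 to compound 4 (2.15 log units; beyond the scatter), so thiophen-3-yl alone does not secure a measurable value. On these data alone, whether thiophen-2-yl would give a number alongside methoxy or methyl stays open. So does how an amine or ethoxy would read in place of methylsulfanyl.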